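Fluorine Beside the Carboxylic Acid: A Step in Efficacy

The source may hold more compounds than are shown below. What is called first, only, known or untested is meant among the compounds shown, and "the series" means these compounds.

The measured compounds and their values:

Compound 1, `Cc1c(OCCCCOc2cccc(C(=O)O)c2)ccc(C(=O)CC(C)C)c1C`, gives 18.3%.
Compound 2, `CCCC(=O)c1ccc(OCCCCOc2ccc(C(=O)O)cc2C)c(C)c1O`, gives 40.5%.
Compound 3, `Cc1c(OCCCCOc2cccc(C(=O)O)c2)ccc(C(=O)CC(C)C)c1O`, gives 69.9%.

All three were tested in an assay on HEK293 cells for positive allosteric modulation of metabotropic glutamate receptor 3 (Rattus norvegicus), read by thallium flux, with a stated time of 2.5 min; on this read-out higher numbers stand for larger maximal responses and lower numbers for smaller maximal responses. On these numbers compound 1 stands lowest of the three: compound 2 lies above it by a margin beyond the scatter, and compound 3 lies furthest above it. Within the data shown here, the one step recorded among the measured compounds is a number 51.6 percentage points higher from compound 1 to compound 3 (beyond the scatter), a large increase in maximal response. The change in that step sits on the core itself.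

Compound 4, `Cc1c(OCCCCOc2ccc(F)c(C(=O)O)c2)ccc(C(=O)CC(C)C)c1C`, is the compound not yet measured. It differs from compound 1 in a single place: fluoro in place of hydrogen on an aromatic carbon. The new group sits ortho to a carboxy group on the ring at the far end of the four-carbon linker.

Among the measured compounds shown here, no measured step concerns this change. For the measured compounds named here, the only step on record involves a different group, hydroxy in place of methyl, at a different ring, so it offers no guide to what a fluoro in place of hydrogen does here. The values of compound 1 and compound 2 differ at several places at once and cannot be read as a step either. Without a comparable precedent, the expectation is a step from compound 1 to compound 4 of a number 1.7 percentage points higher from compound 1 to compound 4 (within the scatter), none beyond the scatter. Compound 4 is therefore estimated at 20%, within a range from 8% to 40%.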

Compound 4, largest response reached (reported as percent of maximum), in percent of the reference or control that the assay uses: 13.8%
The estimate for compound 4 lay 6.2 percentage points above the measured number; the range from low to high includes it.
By their numbers in this assay, from the lowest: compounds 4 and 1 (each within the scatter of the next); then compound 2; then compound 3.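

In this assay, fluoro in place of hydrogen, ortho to the carboxy group, gives a number 4.5 percentage points lower from compound 1 to compound 4 (within the scatter), so the change leaves the maximal response indistinguishable from that of the parent compound. Among these compounds, this is the first reading for a change on the ring that carries the carboxy group, since the one earlier step, a number 51.6 percentage points higher from compound 1 to compound 3 (beyond the scatter), came from hydroxy in place of methyl on an aromatic carbon elsewhere in the molecule. Nothing else shown here bears on this result.

On these data alone, a single fluoro atom at this place says little about other groups there, so it remains open whether a chloro, a methoxy or an amine at the same carbon would also leave the response unchanged, or whether any of them would move it beyond the scatter. As far as these compounds go, it is also open whether fluoro would have as little effect on the hydroxy-bearing compound 3, which gives 69.9% and so has far more room to fall than the low-response compound 1, which gives 18.3% in this assay.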